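A few compounds are considered here, and "the series" means these few. Any claim that something is new, unique, unknown or untested is made for them only; others in the source may bear on it.

Measured so far in a functional assay on the whole organism for antagonist activity, with Mus musculus as the target (a lower number here means that less compound is needed, a higher number that more compound is needed for the effect), as follows:
- compound 1 `CCC(=O)N(c1ccc(Cl)c(Cl)c1)C1CCCC1O` gives 9 mg/kg as its value
- compound 2 `CCCC(=O)N(c1ccccc1)C1CCCC1N(C)C` gives 10 mg/kg as its value
- compound 3 `CCC(=O)N(c1cccc(Cl)c1)C1CCCC1N(C)C` gives 0.2 mg/kg as its value

Compound 1 lies within the scatter of compound 2, while compound 3 has a lower number, beyond the scatter. Next in the series is compound 4 `CCNC1CCCC1N(C(=O)CC)c1ccc(Cl)c(Cl)c1`, which differs from compound 1 by ethylamino in place of hydroxy on a saturated ring carbon and has no value yet. Going by the values given here, no step between measured compounds isolates this change, so any expectation is indirect. Compound 3, which carries an amino group on the ring, gives 0.2 mg/kg in this assay as its value. Compound 2 also carries one and gives 10 mg/kg as its value, so it goes against any rule that such a group alone brings a low number. A moderate move to a lower number is therefore expected, though a change within the scatter is not excluded. The expected size is a 4.5-fold lower number from compound 1 to compound 4 (0.65 log units; beyond the scatter) as an estimate. For compound 4 the estimated value is 2 mg/kg with an expected range of 0.3 mg/kg to 10 mg/kg as the working figure.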

Compound 4, dose for half-maximal effect: 2 mg/kg
For compound 4 middle estimate and measured number coincide at the digits printed; low and high end bracket the measured number.
By their numbers in this assay, from the lowest: compound 3; then compound 4; then compounds 1 and 2 (each within the scatter of the next).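

Ethylamino in place of hydroxy on a saturated ring carbon, next to the ring atom that bears a large group, gives in this assay a 4.5-fold lower number from compound 1 to compound 4 (0.65 log units; beyond the scatter), the first step in the series that isolates a change at this position. The step shows that this position accepts a group of 3 heavy atoms in place of 1 heavy atom without a loss in this read-out, while the hydrogen-bond donor and acceptor counts of the entering and leaving groups stay the same. No measurement is available here that accounts for the step.

From the compounds shown here alone, whether a smaller methylamino group or a longer propylamino chain on this ring carbon would give a lower or higher number remains open. Also open, going by these compounds, is how a carboxylic acid would behave at this position, and whether the step holds without the two chloro substituents of compound 4.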